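Bis-amidine analogues: cytotoxicity on rat myoblasts

The source may hold more compounds than are shown below. What is called first, only, known or untested is meant among the compounds shown, and "the series" means these compounds.

Compound 1 `N=C(N)c1cc(I)c(OCc2cccc([N+](=O)[O-])c2)c(I)c1` is measured in an ADME assay on L6 cells (Rattus norvegicus) for cytotoxicity, read by resazurin assay, with a stated time of 72 h (on this read-out higher numbers stand for weaker inhibition and lower numbers for stronger inhibition), at 7720000 nM. Compound 3 `N=C(N)c1cccc(COc2c(I)cc(C(=N)N)cc2I)c1` gives 19300000 nM in this assay, and the step of a 2.5-fold higher number from compound 1 to compound 3 (0.40 log units; beyond the scatter) rests on the change (a group of 3 heavy atoms (1 carbon, 2 nitrogen; no ring) in place of a group of 3 heavy atoms (1 nitrogen, 2 oxygen; no ring), on an aromatic carbon). Compound 2 `N=C(N)c1ccc(COc2cccc([N+](=O)[O-])c2)cc1` gives 57800000 nM in this assay, the highest of the three numbers; the difference between the core of compound 2 and the core of compound 1 is not broken down here. Compound 4 `N=C(N)c1ccc(COc2cccc(C(=N)N)c2)cc1` is not yet measured. It differs from compound 2 by a group of 3 heavy atoms (1 carbon, 2 nitrogen; no ring) in place of a group of 3 heavy atoms (1 nitrogen, 2 oxygen; no ring), on an aromatic carbon, the same change that separates compound 1 from compound 3. For the measured compounds named here, for compound 4 a step of about a 2.4-fold higher number from compound 2 to compound 4 (0.38 log units; beyond the scatter) is expected, beside the earlier one, because the single precedent is a 2.5-fold higher number from compound 1 to compound 3 (0.40 log units; beyond the scatter). Compound 4 is therefore estimated at 140000000 nM, within 60000000 nM to 350000000 nM.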

Compound 4, half-maximal inhibitory concentration: 19300000 nM
The estimate for compound 4 lay 7.3-fold (0.86 log units) above the measured number; the measured number lies below the stated range.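

In this assay, putting the group of 3 heavy atoms (1 carbon, 2 nitrogen) in place of nitro gives a 3.0-fold lower number from compound 2 to compound 4 (0.48 log units; beyond the scatter). On these two cores the same change runs in opposite directions, so a step read on one core does not carry over to the other in this series: the same change on two cores in this assay, a 2.5-fold higher number (0.40 log units; beyond the scatter) from compound 1 to compound 3 and a 3.0-fold lower number (0.48 log units; beyond the scatter) from compound 2 to compound 4, 7.5-fold (0.87 log units) apart, beyond the scatter of two such steps
For the compounds shown here, with only two pairs, this does not show which difference between the cores sets the direction, nor how the change behaves on any further core.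

As far as these compounds go, whether the iodine atoms of compound 1 and compound 3 have any part in the reversal remains open. So does how other groups in place of nitro, such as an amine, a carboxylic acid or a nitrile, would behave on each core.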